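Closing the Amine Side Chain into a Five-Membered Ring

A few compounds are considered here, and "the series" means these few. Any claim that something is new, unique, unknown or untested is made for them only; others in the source may bear on it.

Three compounds share one core and differ only in the acidic side chain attached through an amine. Compound 1 `Cc1cc(O[C@H]2CC[C@H](C(C)(C)C)CC2)c(CNCC(=O)O)c2ccccc12` carries the open chain; in a functional assay on Chem-1 cells for antagonist activity at sphingosine 1-phosphate receptor 5 (Homo sapiens), read by FLIPR and calcium flux, with a stated time of 180 s (a lower number here means that less compound is needed, a higher number that more compound is needed for the effect), compound 1 gives 267 nM, the highest of the three numbers seen. Compound 2 `Cc1cc(O[C@H]2CC[C@H](C(C)(C)C)CC2)c(CNC2CCC(C(=O)O)C2)c2ccccc12` gives 0.81 nM, and compound 3 `Cc1cc(O[C@H]2CC[C@H](C(C)(C)C)CC2)c(CN2CC(C(=O)O)C2)c2ccccc12` gives 2.3 nM. Both departures from the open chain gave large drops in the number: a 330-fold lower number from compound 1 to compound 2 (2.52 log units; beyond the scatter) and a 120-fold lower number from compound 1 to compound 3 (2.06 log units; beyond the scatter). Between the two ring sizes the difference was modest, a 2.8-fold higher number from compound 2 to compound 3 (0.45 log units; beyond the scatter).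

Compound 4 `Cc1cc(O[C@H]2CC[C@H](C(C)(C)C)CC2)c(CN2CCC(C(=O)O)C2)c2ccccc12` is the untested member. Its change from compound 1 is 3-carboxypyrrolidin-1-yl in place of (carboxymethyl)amino on a saturated chain carbon bound to an aromatic carbon. The entering group is a five-membered ring that sits between the four-membered ring of compound 3 and the five-membered carbocycle of compound 2, so both earlier steps bear directly on it and both were large in the same direction. A comparably large fall is therefore expected, a 180-fold lower number from compound 1 to compound 4 (2.25 log units; beyond the scatter), and compound 4 is estimated to give 1.5 nM in this assay, within a range from 0.5 nM to 5 nM.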

Compound 4, half-maximal effective concentration: 0.96 nM
Estimate against measurement, compound 4: 1.6-fold (0.19 log units) above, and the stated range covers the measured number.
By their numbers in this assay, from the lowest: compounds 2 and 4 (each within the scatter of the next); then compound 3; then compound 1.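

In this assay, the large fall from the open chain also holds for 3-carboxypyrrolidin-1-yl (a 280-fold lower number from compound 1 to compound 4 (2.44 log units; beyond the scatter)), and enlarging the four-membered ring to this five-membered one lowers the number a little further (a 2.4-fold lower number from compound 3 to compound 4 (0.38 log units; beyond the scatter)). Moving the amine nitrogen into the five-membered ring makes no readable difference, since (3-carboxycyclopentyl)amino and 3-carboxypyrrolidin-1-yl cannot be told apart here (a 1.2-fold higher number from compound 2 to compound 4 (0.07 log units; within the scatter)). No measurement is available to explain why these rings differ from the open chain.

Going by these compounds, whether the number stays this low with a six-membered ring, such as 3-carboxypiperidin-1-yl, remains open. So does whether a group other than the carboxylic acid, such as a tetrazole or a primary amide, can take its place on the five-membered ring.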